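From 4-methoxyphenyl to 4-chlorophenyl

A few compounds are considered here, and "the series" means these few. Any claim that something is new, unique, unknown or untested is made for them only; others in the source may bear on it.

Values in an ADME assay on HepG2 cells (Homo sapiens) for cytotoxicity, read by fluorescence and resazurin assay, with a stated time of 24 h; a higher number here means that more compound is tolerated, a lower number that less compound is tolerated
compound 1 `COc1ccccc1-c1nnc(SC2=CS(=O)(=O)c3ccccc32)o1` gives 16000 nM
compound 2 `COc1ccc(-c2nnc(SC3=CS(=O)(=O)c4ccccc43)o2)cc1` gives 22000 nM

Compound 2 at 22000 nM stands within the scatter of compound 1, so the two cannot be told apart. Compound 3 `O=S1(=O)C=C(Sc2nnc(-c3ccc(Cl)cc3)o2)c2ccccc21` carries chloro in place of methoxy on an aromatic carbon, para to a large group (chloro in place of methoxy on an aromatic carbon). Going by the values given here, the only measured step, a 1.4-fold higher number from compound 1 to compound 2 (0.14 log units; within the scatter), swaps 2-methoxyphenyl for 4-methoxyphenyl and never removes the methoxy. It bears only loosely on this change, and no step beyond the scatter is expected in this assay. The estimate implies a 1.1-fold lower number from compound 2 to compound 3 (0.04 log units; within the scatter). For compound 3 the expected value is 20000 nM, with an estimated range from 9000 nM to 40000 nM.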

Compound 3, half-maximal cytotoxic concentration: 22000 nM
The estimate for compound 3 lay 1.1-fold (0.04 log units) below the measured number; low and high end bracket the measured number.
By their numbers in this assay, from the lowest: compounds 1, 2 and 3 (each within the scatter of the next).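

In this assay, chloro in place of methoxy on an aromatic carbon, para to a large group, gives no change at the digits printed from compound 2 to compound 3 (within the scatter). Thus, the first replacement of the methoxy itself leaves the number unresolved from that of compound 2, and the comparison with the 2-methoxyphenyl compound gives a 1.4-fold higher number from compound 1 to compound 3 (0.14 log units; within the scatter). Nothing available accounts for this result.

On these data alone, whether any group in this place can move the number beyond the scatter remains open. An amine or a carboxylic acid there would test this, as would a longer chain.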